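The compounds below may be only part of what the source reports. "The series", "measured", "known", "first", "only" and "open" are said of these compounds alone.

Of the compounds shown here, three sharing one core have been measured in an assay on isolated protein for inhibition of serine/threonine-protein kinase PAK 1 (Homo sapiens), read by ADP-Glo, with a stated time of 40 min; on this read-out lower numbers stand for stronger inhibition and higher numbers for weaker inhibition. Compound 1 `O=C(NC1CCN(c2ncnc3[nH]ncc23)CC1)c1ccccc1Cl` gives 5240 nM. Compound 2 `O=C(NC1CCN(c2ncnc3[nH]ncc23)CC1)c1cccc(Cl)c1Cl` gives 4170 nM, and the step of a 1.3-fold lower number from compound 1 to compound 2 (0.10 log units; within the scatter) shows that the added chloro changes little. Compound 3 `Cc1cccc(C)c1NC(=O)NC1CCN(c2ncnc3[nH]ncc23)CC1`, the urea, gives 2160 nM, the smallest of the three numbers; the step of a 2.4-fold lower number from compound 1 to compound 3 (0.38 log units; beyond the scatter) is modest, while the step of a 1.9-fold lower number from compound 2 to compound 3 (0.29 log units; within the scatter) does not separate compound 3 from compound 2.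

Compound 4 `COc1ccc(NC(=O)NC2CCN(c3ncnc4[nH]ncc34)CC2)cc1` is the next urea. The change is 4-methoxyphenyl in place of 2,6-dimethylphenyl on an amide-type nitrogen. Within the data shown here, none of the measured steps touches the aryl group of a urea: the steps from compound 1 and compound 2 to compound 3 swap an amide for a urea, and the step within the amides adds a chloro. Among the measured compounds shown here, the only guide is that trading one small aryl group for another, as between compound 1 and compound 2, stayed within the scatter. On that basis the step of a 1.2-fold higher number from compound 3 to compound 4 (0.06 log units; within the scatter) is expected to stay within the scatter. Compound 4 is therefore estimated at 2500 nM, within a range from 900 nM to 7000 nM.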

Compound 4, half-maximal inhibitory concentration: 6370 nM
Compound 4: the middle estimate sits 2.5-fold (0.41 log units) below what was measured; measured number inside the range.
By their numbers in this assay, from the lowest: compounds 3, 2, 1 and 4 (each within the scatter of the next, the first and the last beyond it).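

Among these compounds, this is the first step that changes the aryl group of a urea, and it shows that the group on this amide-type nitrogen is not freely interchangeable: 4-methoxyphenyl in place of 2,6-dimethylphenyl moves the number beyond the scatter (a 2.9-fold higher number from compound 3 to compound 4 (0.47 log units; beyond the scatter)). Being a urea is also not enough on its own, since compound 4 is not separated from either amide (a 1.5-fold higher number from compound 2 to compound 4 (0.18 log units; within the scatter); a 1.2-fold higher number from compound 1 to compound 4 (0.08 log units; within the scatter)), whereas compound 3 stands apart from compound 1. Nothing measured here accounts for the effect of this swap.

The two aryl groups differ in more than one feature, so the compounds shown cannot tell whether the gain of the methoxy or the loss of the two methyl groups matters. As far as these compounds go, how a plain phenyl or a 4-methylphenyl would read on this nitrogen remains open.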